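Thiophene for Chlorophenyl on a Second Dithiocarbamate Core

The source may hold more compounds than are shown below. What is called first, only, known or untested is meant among the compounds shown, and "the series" means these compounds.

Measured compounds:
compound 1, `O=C(/C=C/c1cccs1)c1ccc(OCCSC(=S)N2CCCC2)cc1`, 19100 nM
compound 2, `O=C(/C=C/c1ccc(Cl)cc1)c1ccc(OCCSC(=S)N2CCCC2)cc1`, 18300 nM
compound 3, `O=C(/C=C/c1ccc(Cl)cc1)c1ccc(OCCCSC(=S)N2CCCCC2)cc1`, 32200 nM

All three numbers come from a functional assay on SK-N-SH cells (Homo sapiens) for inhibition, read by MTT assay, with a stated time of 72 h; a lower number here means a stronger inhibitor, a higher number a weaker inhibitor. Compound 1 and compound 2 share one core, while compound 3 carries a different one; the difference between the two cores is a group of 10 heavy atoms (7 carbon, 1 nitrogen, 2 sulfur; one six-membered non-aromatic ring with 1 hetero atom) in place of a group of 8 heavy atoms (5 carbon, 1 nitrogen, 2 sulfur; one five-membered non-aromatic ring with 1 hetero atom), on a saturated chain carbon, two bonds along the chain from an oxygen on an aromatic ring. In this assay a 1.8-fold higher number from compound 2 to compound 3 (0.25 log units; within the scatter), so the two cores cannot be told apart on the numbers in hand. Within the core of compound 2, the change that leads to compound 1 is thiophen-2-yl in place of 4-chlorophenyl on a double-bonded chain carbon bound to a double-bonded chain carbon, and this assay shows a 1.0-fold higher number from compound 2 to compound 1 (0.02 log units; within the scatter).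

Compound 4, `O=C(/C=C/c1cccs1)c1ccc(OCCCSC(=S)N2CCCCC2)cc1`, has not been measured. It stands to compound 3 as compound 1 stands to compound 2: the change is thiophen-2-yl in place of 4-chlorophenyl on a double-bonded chain carbon bound to a double-bonded chain carbon, and since the place is described in the same words in both cases it is the same change on the other core. Within the data shown here, the only guide to its effect is the earlier pair, where this assay gave a 1.0-fold higher number from compound 2 to compound 1 (0.02 log units; within the scatter). On that basis compound 4 is expected to show a 1.0-fold lower number from compound 3 to compound 4 (0.02 log units; within the scatter). This expectation rests on one pair of compounds and on the value of compound 3, 32200 nM, and it carries the uncertainty of a single precedent. Compound 4 is estimated at 31000 nM, with the range from 15000 nM to 65000 nM expected to hold most repeat measurements.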

Compound 4, half-maximal inhibitory concentration: 38200 nM
Estimate against measurement, compound 4: 1.2-fold (0.09 log units) below; the measured number falls inside the stated range.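

In this assay, putting thiophen-2-yl in place of 4-chlorophenyl on the core of compound 3 gives a 1.2-fold higher number from compound 3 to compound 4 (0.07 log units; within the scatter), and this step can be set directly beside the one seen on the core of compound 2: the same change on two cores in this assay, a 1.0-fold higher number (0.02 log units; within the scatter) from compound 2 to compound 1 and a 1.2-fold higher number (0.07 log units; within the scatter) from compound 3 to compound 4, 1.1-fold (0.06 log units) apart, within the scatter of two such steps. The change therefore behaves alike on both cores, and in neither case does it move the number by more than repeat measurements would be expected to. Among these compounds, this is agreement between two flat steps, resting on only two pairs in a single cell assay, so it shows that the swap is tolerated on both cores but does not show that a change with a real effect would carry from one core to the other.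

The two cores differ as a single group, so the compounds shown do not separate the contribution of the ring on the dithiocarbamate from that of the chain carrying it. Also open, on these data alone, is whether another aryl group, such as 4-methoxyphenyl or furan-2-yl, or a morpholine in place of the non-aromatic ring, would shift the number beyond the scatter on either core.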